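The source may report more compounds than this note shows. Statements on the series, on what has been measured and on what is new or still open speak of the compounds shown alone.

Working notes on the series in a functional assay on DU-145 cells (Homo sapiens) for inhibition, read by trypan blue exclusion, with a stated time of 96 h; on this read-out lower numbers stand for stronger inhibition of growth and higher numbers for weaker inhibition of growth. Among the compounds with values here, compound 1 (`Cc1ccc(CS(=O)(=O)/C(=C/c2cc(C)cc(C)c2)C(=O)c2ccc(Cl)cc2)cc1`) gives 10000 nM, the highest of the three numbers so far. Compound 2 (`O=C(/C(=C\c1ccc(Br)cc1)Sc1ccc(Br)cc1)c1ccc(Br)cc1`) gives 1000 nM and compound 3 (`Cc1cc(C)cc(/C=C(\C(=O)c2ccc(Cl)cc2)S(=O)(=O)Cc2ccc(Cl)cc2)c1`) gives 1000 nM, so both lie beyond the scatter on the lower side of compound 1.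

The next change leads to compound 4 (`Cc1ccc(CS(=O)(=O)/C(=C/c2c[nH]c3ccccc23)C(=O)c2ccc(Cl)cc2)cc1`): 1H-indol-3-yl in place of 3,5-dimethylphenyl on a double-bonded chain carbon bound to a double-bonded chain carbon. Within the data shown here, the only measured step at a single place is a 10-fold lower number from compound 1 to compound 3 (1.00 log units; beyond the scatter), a modest one, with chloro in place of methyl on an aromatic carbon. That step does not touch the double-bonded chain carbon, so it bears on the new change only as a guide to size. Compound 2 differs from compound 1 in more than one place and isolates nothing. Among the measured compounds shown here, no measurement yet shows what an exchange at this carbon does in this assay.

Compound 1 stands at the top of the numbers, so a move towards a lower number is the more likely direction, though the data cannot exclude a result within the scatter. The size of the step to compound 3, at 1000 nM, is taken as the upper guide. The estimate is therefore a 3.3-fold lower number from compound 1 to compound 4 (0.52 log units; beyond the scatter), smaller than that measured step. For compound 4 the expected value is 3000 nM, with an estimated range from 600 nM to 12000 nM.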

Compound 4, concentration for 50% growth inhibition: 25000 nM
The estimate for compound 4 lay 8.3-fold (0.92 log units) below the measured number; measured number outside the range, above it.
By their numbers in this assay, from the lowest: compounds 2 and 3 (each within the scatter of the next); then compound 1; then compound 4.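

In this assay, within the data shown here, a 2.5-fold higher number from compound 1 to compound 4 (0.40 log units; beyond the scatter) is the first measured step at the double-bonded chain carbon bound to a double-bonded chain carbon, and it shows that the number does respond to an exchange at this place. Among these compounds, its direction is towards weaker inhibition of growth, opposite to that of the only earlier single-place step, a 10-fold lower number from compound 1 to compound 3 (1.00 log units; beyond the scatter), which was made elsewhere on the core. Within the core of compound 1, 1H-indol-3-yl therefore gives weaker inhibition of growth than 3,5-dimethylphenyl, but no measurement here bears on the reason for this step.

The exchange alters the ring system and also brings in a nitrogen and a hydrogen-bond donor, and this single step does not separate these changes; a phenyl carrying an amine or a methoxy group at this carbon would bear on that question. Going by these compounds, it also remains open whether 1H-indol-3-yl gives a step of the same direction and size on the core of compound 3, which carries chloro in place of methyl.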